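Changing the group on the carbonyl carbon

The compounds below may be only part of what the source reports. "The series", "measured", "known", "first", "only" and "open" are said of these compounds alone.

Three compounds share one core and differ only in the group attached to a carbonyl carbon that also carries an amide-type nitrogen. Compound 1 `CC(=O)N(O)C(C)c1ccc2oc(-c3ccccc3)cc2c1` carries a methyl there; in an assay on RBL cells for inhibition of Polyunsaturated fatty acid 5-lipoxygenase (Rattus norvegicus) (on this read-out lower numbers stand for stronger inhibition and higher numbers for weaker inhibition), compound 1 gives 490 nM. Compound 2 `CC(c1ccc2oc(-c3ccccc3)cc2c1)N(O)C(=O)c1ccccc1` carries a phenyl, and in this assay compound 2 gives 4830 nM. Compound 3 `CC(c1ccc2oc(-c3ccccc3)cc2c1)N(O)C(=O)c1cccs1` carries a thiophen-2-yl, and in this assay compound 3 gives 250 nM. Compound 3 has the lowest number of the three: a 2.0-fold lower number from compound 1 to compound 3 (0.29 log units; within the scatter) is within the scatter, so compound 1 and compound 3 cannot be told apart, whereas a 19-fold lower number from compound 2 to compound 3 (1.29 log units; beyond the scatter) is a large step. Compound 4 `CCOC(=O)CCC(=O)N(O)C(C)c1ccc2oc(-c3ccccc3)cc2c1` takes the next step from compound 3: 2-(ethoxycarbonyl)ethyl in place of thiophen-2-yl on a carbonyl carbon. Going by the values given here, no measured step puts a chain in this place, so the earlier steps bear on it only indirectly. a 9.9-fold higher number from compound 1 to compound 2 (0.99 log units; beyond the scatter) shows that a larger group on this carbon can raise the number, while a 19-fold lower number from compound 2 to compound 3 (1.29 log units; beyond the scatter) shows that the kind of ring matters a great deal. The entering chain has no ring, and compound 1 with its methyl, at 490 nM, seems the closest guide. Judged against these steps, a modest rise is expected, a 3.2-fold higher number from compound 3 to compound 4 (0.51 log units; beyond the scatter). Compound 4 is therefore estimated at 800 nM, with a range from 200 nM to 3500 nM.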

Compound 4, half-maximal inhibitory concentration: 50 nM
Beside the measured number, compound 4's estimate is 16-fold (1.20 log units) above it; the measured number lies below the stated range.
By their numbers in this assay, from the lowest: compound 4; then compounds 3 and 1 (each within the scatter of the next); then compound 2.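

Among the methyl, phenyl and thiophen-2-yl groups, the two lowest numbers could not be told apart, but in this assay the open chain 2-(ethoxycarbonyl)ethyl moves clearly past both, with a 5.0-fold lower number from compound 3 to compound 4 (0.70 log units; beyond the scatter) and a 9.8-fold lower number from compound 1 to compound 4 (0.99 log units; beyond the scatter). A ring is therefore not needed on this carbonyl carbon for a low number, and a larger group need not raise it: extending the methyl into this chain lowers the number, while replacing the methyl with phenyl goes the other way, and a 97-fold lower number from compound 2 to compound 4 (1.98 log units; beyond the scatter) is the largest step in the set. Nothing available here explains why this chain gives the lowest number.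

The compounds shown do not separate the contribution of the chain from that of its ethoxycarbonyl end, so a plain butyl chain, a carboxylic acid or a primary amide in this place would be the informative comparisons. Also open, as far as these compounds go, is how the number responds to a shorter or longer chain ending in the same ethoxycarbonyl group, and whether a saturated ring such as cyclohexyl behaves like the chain or like the aromatic rings.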